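This account rests on a few compounds, and the source may have more. Where it says the series, first, only, none or still open, it means among the compounds named here.

Measured so far:
Compound 1 `Nc1cc(N)c2nc(-c3ccccc3)c(NCc3ccc(Cl)c(Cl)c3)nc2c1` gives < 100000 nM in a functional assay on SR cells (Homo sapiens) for inhibition, read by sulforhodamine B assay, with a stated time of 48 h; a higher number here means that more compound is tolerated, a lower number that less compound is tolerated; this is a limit of the assay, not a number.
Compound 2 `Nc1cc(N)c2nc(-c3ccccc3)c(Sc3ccc(F)cc3)nc2c1` gives < 100000 nM in this assay; this too is a limit.
Compound 3 `COc1cc(CNc2nc3cc(N)cc(N)c3nc2-c2ccccc2)cc(OC)c1OC` gives < 50200 nM in this assay; again only a limit.

Compound 2 therefore stands on no measured number at all, only at the limit of < 100000 nM in this assay, at which 2 of the 3 values shown sit, shared with compound 1, while compound 3 sits at the limit of < 50200 nM in this assay, at which 1 of the 3 values shown sits. Going by the values given here, no step between two measured compounds exists in this set. Compound 4 `Nc1cc(N)c2nc(-c3ccccc3)c(Sc3ccc(Cl)c(Cl)c3)nc2c1` is not yet measured and differs from compound 2 in one place: 3,4-dichlorophenyl in place of 4-fluorophenyl on a sulfur. Among the compounds with values here, with every measured value a limit and no measured step to go on, the step that the limit leaves unreadable from compound 2 to compound 4 is expected to be none beyond the usual scatter of this assay. Compound 4 is estimated at 80000 nM, between 20000 nM and 150000 nM, and most likely reported again only as a limit.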

Compound 4, concentration lethal to 50% of the cells: < 100000 nM
Compound 4: no number, only a limit (the forecaster's own chance of this, stated with the estimate: 70%); the middle value lies beyond the limit too.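

In this assay compound 4 gives < 100000 nM, only a limit. Going by these compounds alone, compound 2 gives < 100000 nM, also a limit, so no step between compound 2 and compound 4 can be read. Going by these compounds, whether 3,4-dichlorophenyl in place of 4-fluorophenyl on a sulfur changes the read-out stays open.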